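This account rests on a few compounds, and the source may have more. Where it says the series, first, only, none or still open, it means among the compounds named here.

Compound 1 `Cc1ccc(S(=O)(=O)NC(=O)[C@@H](NC2=NC(=O)/C(=C/c3ccccc3Cl)S2)C(C)C)cc1` stands level with compound 2 `Cc1ccc(S(=O)(=O)NC(=O)[C@@H](NC2=NC(=O)/C(=C/c3ccccc3)S2)C(C)C)cc1`: in a functional assay on PC-3 cells (Homo sapiens) for antiproliferative activity, read by MTT assay, with a stated time of 48 h (on this read-out lower numbers stand for stronger inhibition and higher numbers for weaker inhibition), compound 1 gives 11.9 ug/mL, and compound 2 gives 11.9 ug/mL, the step of no change at the digits printed from compound 1 to compound 2 (within the scatter) lying within the scatter. Compound 3 `Cc1ccc(S(=O)(=O)NC(=O)[C@H](CC(C)C)NC2=NC(=O)/C(=C/c3ccccc3Cl)S2)cc1` differs from compound 1 by isobutyl in place of isopropyl on a saturated chain carbon bound to an amine nitrogen and a carbonyl carbon. Among the compounds with values here, no measured step alters that saturated chain carbon; the only known step, hydrogen in place of chloro on an aromatic carbon, was flat, so nothing points to a shift beyond the scatter in this assay. The estimate for compound 3 is therefore 12 ug/mL, between 6 ug/mL and 25 ug/mL. The expected step is a 1.0-fold higher number from compound 1 to compound 3 (0.00 log units; within the scatter).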

Compound 3, half-maximal inhibitory concentration: 15.6 ug/mL
For compound 3 the middle estimate is 1.3-fold (0.11 log units) below the measured one, within the range that was stated.
By their numbers in this assay, from the lowest: compounds 1, 2 and 3 (each within the scatter of the next).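

Within the data shown here, at the saturated chain carbon bound to an amine nitrogen and a carbonyl carbon, the first measured change in this assay gives a 1.3-fold higher number from compound 1 to compound 3 (0.12 log units; within the scatter) for isobutyl in place of isopropyl. Swapping one of these branched chains for the other therefore leaves the number within the scatter at this position, as the hydrogen for chloro change on the aromatic carbon did. Nothing available explains this result.

The compounds shown leave open whether a benzyl group, a carboxylic acid or an amine on that carbon would move the number beyond the scatter. They also leave open whether isobutyl gives the same result in the compound lacking chloro.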